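Series notes: triazole thioether and sulfone amides

A few compounds are considered here, and "the series" means these few. Any claim that something is new, unique, unknown or untested is made for them only; others in the source may bear on it.

Measured so far:
compound 1 `CN(C(=O)CSc1nnc(Cc2nn(C)c(=O)c3ccccc23)n1C)c1ccc(Cl)cc1Cl` — > 30000 nM
compound 2 `Cn1c(Cc2nn(C)c(=O)c3ccccc23)nnc1S(=O)(=O)CCCCCCCC(=O)Nc1ccc(Br)cc1Br` — 1400 nM
compound 3 `CN(C(=O)CCCCCCCSc1nnc(Cc2nn(C)c(=O)c3ccccc23)n1C)c1ccc(Cl)cc1Cl` — 11900 nM

In an assay on isolated protein (Mus musculus) for inhibition of IL15-IL15 receptor (Homo sapiens), read by resazurin assay, with stated times of 30 min and 2.5 days (a higher number here means a weaker inhibitor, a lower number a stronger inhibitor), compound 1 gives only a limit, > 30000 nM, and no number. Among the measured compounds shown here, compound 1 therefore stands at the weak end of what has been measured, as the one value among the three that sits at the limit of > 30000 nM in this assay, at which 1 of the 3 values shown sits. Compound 3, which carries the same amine on a longer chain, gives 11900 nM in this assay, and compound 2, a sulfone with a long chain and a (2,4-dibromophenyl)amino amide, gives 1400 nM.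

The next compound, compound 4 `Cn1c(Cc2nn(C)c(=O)c3ccccc23)nnc1SCC(=O)Nc1ccc(Br)cc1Br`, differs from compound 1 in one place: (2,4-dibromophenyl)amino in place of (2,4-dichlorophenyl)(methyl)amino on a carbonyl carbon. For the measured compounds named here, no step between measured compounds covers this exchange. Because compound 2 gives 1400 nM, a step toward stronger inhibition is expected, of the size an at least 2.0-fold lower number from compound 1 to compound 4 (0.30 log units; that floor lies within the scatter), though it could also stay within the scatter. Compound 4 is estimated at 15000 nM, between 4000 nM and 60000 nM in this assay.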

Compound 4, half-maximal inhibitory concentration: > 30000 nM
Compound 4 gave a limit, no number; the forecaster's own chance of this, stated with the estimate: 40%; middle value at least 2.0-fold (0.30 log units) from the limit.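

Among the compounds shown here, compound 1 and compound 4 both give only a limit and no number, so no step between them can be read: the limit of > 30000 nM in this assay, at which 2 of the 4 values shown sit.

The compounds shown leave open whether (2,4-dibromophenyl)amino in place of (2,4-dichlorophenyl)(methyl)amino on a carbonyl carbon changes inhibition at all.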